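Compound 3 in the series: a halogen swap on the aryl end

The compounds below may be only part of what the source reports. "The series", "measured", "known", "first", "only" and "open" are said of these compounds alone.

Two compounds have so far been run through a functional assay on SW-620 cells (Homo sapiens) for inhibition, read by MTT assay, with a stated time of 72 h; a lower number here means a stronger inhibitor, a higher number a weaker inhibitor. In this assay compound 1 `COc1cc(NC(C)CCCNC(=O)Nc2ccc(F)cc2)c2ncccc2c1` gives 25000 nM, and compound 2 `COc1cc(NC(C)CCCNC(=O)NNC(=O)Nc2ccc(Br)cc2)c2ncccc2c1` gives 17000 nM. For the measured compounds named here, the only step connecting them, a 1.5-fold lower number from compound 1 to compound 2 (0.17 log units; within the scatter), lies within the scatter, so compound 2 stands alongside compound 1 with no separation that can be read as real; neither compound can be set apart from the other on these numbers.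

Compound 3 `COc1cc(NC(C)CCCNC(=O)NNC(=O)Nc2cccc(Cl)c2)c2ncccc2c1` is the next one to be measured. It differs from compound 2 in a single place: 3-chlorophenyl in place of 4-bromophenyl on an amide-type nitrogen. Going by the values given here, no measured step bears directly on this change. Among the compounds with values here, the one step that has been measured alters a different part of the molecule, and nothing measured so far isolates a change of halogen or of its position on the aryl ring by itself. Within the data shown here, because compound 2 gives 17000 nM and the only known step of a 1.5-fold lower number from compound 1 to compound 2 (0.17 log units; within the scatter) is within the scatter, the expectation for compound 3 is a step of a 1.2-fold higher number from compound 2 to compound 3 (0.07 log units; within the scatter), that is, nothing beyond the scatter. The estimate for compound 3 in this assay is therefore 20000 nM, with a range from 8000 nM to 50000 nM.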

Compound 3, half-maximal inhibitory concentration: 25000 nM
Estimate against measurement, compound 3: 1.3-fold (0.10 log units) below, and the stated range covers the measured number.
By their numbers in this assay, from the lowest: compounds 2, 1 and 3 (each within the scatter of the next).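

In this assay, for the compounds shown here, the step of a 1.5-fold higher number from compound 2 to compound 3 (0.17 log units; within the scatter) is the first measured change confined to the aryl end of the molecule: 3-chlorophenyl in place of 4-bromophenyl on an amide-type nitrogen, with the halogen and its place on the ring changing together, and this double change does not separate the two compounds. The second new step, no change at the digits printed from compound 1 to compound 3 (within the scatter), comes with a larger replacement, which differs in more than the halogen, and this replacement also leaves the two compounds unseparated in this assay. No other data bearing on these results are available, so the reading stops at the numbers themselves.

The halogen and its place on the ring changed in the same step, so the compounds shown cannot tell the contribution of one from that of the other. Going by these compounds, whether an aryl end carrying an amine or a carboxylic acid instead of a halogen would give a step beyond the scatter in this assay remains open.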